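The source may hold more compounds than are shown below. What is called first, only, known or untested is meant among the compounds shown, and "the series" means these compounds.

Compound 1 `CCOC(=O)c1sc(-c2cccc(NC(=O)c3ccccc3)c2)nc1Nc1ccc(N2CCN(C)CC2)cc1` was examined in a functional assay on Raji cells (Homo sapiens) for antiproliferative activity, read by CCK-8 assay, with a stated time of 72 h, tested at 40 uM (a higher number here means more inhibition at the concentration tested (going by the name of the read-out), a lower number less inhibition), where compound 1 gives 42%. Among the three measured compounds it stands second highest. Compound 2 `CCOC(=O)c1sc(-c2cccc(NC(=O)c3ccc(F)c(Cl)c3)c2)nc1Nc1ccc(N2CCN(C)CC2)cc1` gives 20.7%, the change being a number 21.3 percentage points lower from compound 1 to compound 2 (beyond the scatter). Compound 3 `CCOC(=O)c1sc(-c2cccc(NC(=O)c3ccco3)c2)nc1Nc1ccc(N2CCN(C)CC2)cc1` gives 87.6%, a step of a number 45.6 percentage points higher from compound 1 to compound 3 (beyond the scatter); between the other pair the step is a number 66.9 percentage points higher from compound 2 to compound 3 (beyond the scatter). All three of these steps swap the group on a carbonyl carbon of the amide, leaving the rest of the shared core untouched.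

Compound 4 `CN1CCN(c2ccc(Nc3nc(-c4cccc(NC(=O)c5ccccc5)c4)sc3C(=O)O)cc2)CC1` differs from compound 1 elsewhere: hydrogen in place of ethyl on an oxygen next to a carbonyl group. Among the compounds with values here, none of the measured steps touches this oxygen, so none of them bears on the change, and the only anchor is the value of compound 1. Within the data shown here, with no comparable step to lean on, the expectation for compound 4 is an estimated 30% in this assay, within a wide range from 5% to 60%, which means an estimated step of a number 12 percentage points lower from compound 1 to compound 4 (beyond the scatter) that is not expected to exceed the scatter with any confidence.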

Compound 4, a percentage reported as inhibition, at one concentration (the size of the read-out at that concentration, not a potency): 11.9%
The estimate for compound 4 lay 18.1 percentage points above the measured number; the measured number falls inside the stated range.
By their numbers in this assay, from the lowest: compounds 4 and 2 (each within the scatter of the next); then compound 1; then compound 3.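

The earlier steps shown here all changed the group on the amide carbonyl, whereas this one shows that the other end of the molecule also matters in this assay. Swapping ethoxy for hydroxy, which turns the ethoxycarbonyl into a carboxy group, gives a number 30.1 percentage points lower from compound 1 to compound 4 (beyond the scatter). So losing just the ethyl on this oxygen removes much of the inhibition seen with compound 1, and nothing available here explains why.

As far as these compounds go, it remains open whether the ethyl is specifically needed, or whether a methyl, a longer propyl chain or an amine in place of the ethoxy would hold the inhibition. From the compounds shown here alone, it is also open whether the same change would cost as much with the furan-2-yl amide of compound 3.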